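Methyl in Place of Cyano and Cytotoxicity in Two Cores

The source may hold more compounds than are shown below. What is called first, only, known or untested is meant among the compounds shown, and "the series" means these compounds.

Of the compounds shown here, three have been measured in an ADME assay on MT4 cells (Homo sapiens) for cytotoxicity, read by MTT assay, with a stated time of 5 days; on this read-out lower numbers stand for higher toxicity in this test and higher numbers for lower toxicity in this test. Compound 1 `Cc1cc(C)c(Oc2cc(Nc3ccc(C#N)cc3)[nH]c(=O)c2)c(C)c1` gives 32000 nM, compound 2 `COc1cc(Oc2c(C)cc(C)cc2C)cc(Nc2ccc(C#N)cc2)n1` gives 29000 nM, and compound 3 `Cc1ccc(Nc2cc(Oc3c(C)cc(C)cc3C)cc(=O)[nH]2)cc1` gives 37000 nM; the three values lie within the scatter of one another. The difference between the core of compound 1 and the core of compound 2 is not broken down here.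

From compound 1 to compound 3 the change is methyl in place of cyano on an aromatic carbon. This gave a 1.2-fold higher number from compound 1 to compound 3 (0.06 log units; within the scatter).

Compound 4 `COc1cc(Oc2c(C)cc(C)cc2C)cc(Nc2ccc(C)cc2)n1` is not yet measured. It differs from compound 2 in the same way: methyl in place of cyano on an aromatic carbon. Since the step from compound 1 to compound 3 stayed within the scatter, the step from compound 2 to compound 4 in this assay is expected to be of like size, about a 1.2-fold higher number from compound 2 to compound 4 (0.08 log units; within the scatter), resting on the single earlier case of this change and on the value of compound 2, 29000 nM. Compound 4 is therefore estimated at 35000 nM, with a range from 20000 nM to 60000 nM.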

Compound 4, half-maximal cytotoxic concentration: 35000 nM
Beside the measured number, compound 4's estimate shows no gap at the digits printed, and the stated range covers the measured number.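

In this assay the change of cyano to methyl on the aromatic carbon gave a 1.2-fold higher number from compound 2 to compound 4 (0.08 log units; within the scatter), so the second core behaves as the first did. Set side by side, the two steps do not differ, and the change reads the same on both cores: the same change on two cores in this assay, a 1.2-fold higher number (0.06 log units; within the scatter) from compound 1 to compound 3 and a 1.2-fold higher number (0.08 log units; within the scatter) from compound 2 to compound 4, 1.0-fold (0.02 log units) apart, within the scatter of two such steps. This shows only that, on these two cores and in this one assay, the swap from 4-cyanophenyl to 4-methylphenyl left the number within the scatter; it does not show a real effect of the change that carries over, since neither step can be told apart from repeated measurement, and two cases say nothing firm about a third core.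

The compounds shown leave open whether a different group in the same place, such as an amine, a carboxylic acid or a longer chain, would also stay within the scatter. They also leave open whether the agreement would hold for a step large enough to stand clear of the scatter.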